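A Sulfonamide Ring Swap Before the Readout

The compounds below may be only part of what the source reports. "The series", "measured", "known", "first", "only" and "open" are said of these compounds alone.

Compound 1 `Cc1ccc(C(/C=C/c2ccc(F)cc2)=N\Nc2nncc3ccccc23)cc1`: in a functional assay on SF-295 cells (Homo sapiens) for antiproliferative activity, read by sulforhodamine B assay, with a stated time of 72 h (on this read-out lower numbers stand for stronger inhibition and higher numbers for weaker inhibition), compound 1 gives 0.55 nM.
Compound 2 `NC(=S)NNc1nncc2ccccc12`: in this assay compound 2 gives 9.3 nM.
Compound 3 `Cc1cc(NS(=O)(=O)c2ccc(Nc3nncc4ccccc34)cc2)no1`: in this assay compound 3 gives 4.4 nM.

Among these three numbers compound 3 stands second highest. Its nearest neighbour is compound 2, whose higher number lies beyond the scatter; its furthest is compound 1, whose lower number lies well beyond it. Compound 4 `O=S(=O)(Nc1ccccn1)c1ccc(Nc2nncc3ccccc23)cc1` differs from compound 3 in one place: pyridin-2-yl in place of 5-methyl-1,2-oxazol-3-yl on a sulfonamide nitrogen. Going by the values given here, no step between measured compounds is available to guide this change, so the expectation rests on the single swap of one small aromatic ring for another on the same nitrogen. The step of a 1.4-fold higher number from compound 3 to compound 4 (0.13 log units; within the scatter) is expected to be modest, in the direction of a weaker number, and possibly no more than the scatter. Compound 4 is estimated at 6 nM, with a range from 2 nM to 20 nM.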

Compound 4, half-maximal inhibitory concentration: 8.4 nM
Compound 4: the middle estimate sits 1.4-fold (0.15 log units) below what was measured; the range from low to high includes it.
By their numbers in this assay, from the lowest: compound 1; then compounds 3, 4 and 2 (each within the scatter of the next, the first and the last beyond it).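

In this assay the swap on the sulfonamide nitrogen reads as a 1.9-fold higher number from compound 3 to compound 4 (0.28 log units; within the scatter) and so gives the first view of this position: a five-membered aromatic ring with 2 hetero atoms and a six-membered one with 1 hetero atom are not told apart here. This holds for this one pair only, and it shows that the ring can change in size and hetero atoms without a step beyond the scatter. Nothing available bears on why the two compounds read alike.

Going by these compounds, whether a phenyl ring, a carboxylic acid or a longer chain on this nitrogen would read the same remains open. So does the outcome with no ring at all, the bare sulfonamide amine.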